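A few compounds are considered here, and "the series" means these few. Any claim that something is new, unique, unknown or untested is made for them only; others in the source may bear on it.

Of the compounds shown here, three built on one shared core have been measured in a functional assay on BE(2)-C cells (Homo sapiens) for inhibition, read by MTT assay, with a stated time of 72 h; on this read-out higher numbers stand for weaker inhibition of growth and lower numbers for stronger inhibition of growth. Compound 1 `O=S(=O)(NCCCNCc1ccccc1Cl)c1cc(C(F)(F)F)cc(C(F)(F)F)c1` gives 15000 nM, compound 2 `CC(C)(C)c1ccc(CNCCCNS(=O)(=O)c2cc(C(F)(F)F)cc(C(F)(F)F)c2)cc1` gives 2500 nM, and compound 3 `CN(CCCNS(=O)(=O)c1cc(C(F)(F)F)cc(C(F)(F)F)c1)Cc1ccccc1` gives 28000 nM, the highest of the three numbers, though its gap to compound 1 lies within the scatter. Compound 4 `O=S(=O)(NCCCNCc1cccc(Cl)c1)c1cc(C(F)(F)F)cc(C(F)(F)F)c1` is not yet measured. The change leading to it is (3-chlorobenzyl)amino in place of benzyl(methyl)amino on a saturated chain carbon, three bonds along the chain from a sulfonamide nitrogen. For the measured compounds named here, two measured steps bear on this: a 1.9-fold higher number from compound 1 to compound 3 (0.27 log units; within the scatter), which also concerns the amine and the chlorophenyl, and a 6.0-fold lower number from compound 1 to compound 2 (0.78 log units; beyond the scatter), which changes only the group on the aromatic ring. Compound 4 is close in build to compound 1, so a modest fall is expected, a 2.3-fold lower number from compound 3 to compound 4 (0.37 log units; beyond the scatter). Compound 4 is therefore estimated at 12000 nM, between 4000 nM and 40000 nM.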

Compound 4, concentration for 50% growth inhibition: 6900 nM
Compound 4: middle estimate off by 1.7-fold (0.24 log units), on the high side; measured number inside the range.
By their numbers in this assay, from the lowest: compound 2; then compound 4; then compounds 1 and 3 (each within the scatter of the next).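

Moving the chlorine, with 3-chlorophenyl in place of 2-chlorophenyl, changes growth inhibition in this assay by more than the scatter (a 2.2-fold lower number from compound 1 to compound 4 (0.34 log units; beyond the scatter)), so its place on the ring counts here. The larger step (a 4.1-fold lower number from compound 3 to compound 4 (0.61 log units; beyond the scatter)) combines that chlorine with loss of the amine methyl, and these two changes cannot be separated. The 4-(tert-butyl)phenyl group still gives the lowest number (a 2.8-fold higher number from compound 2 to compound 4 (0.44 log units; beyond the scatter)).

No measurement explains these steps. On these data alone, how a 4-chlorophenyl group or a longer chain would compare remains open.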